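Methyl shifted on the outer ring: compound 2 to compound 4

The source may report more compounds than this note shows. Statements on the series, on what has been measured and on what is new or still open speak of the compounds shown alone.

Measured so far:
compound 1 `CS(=O)(=O)c1ccc(-c2cnc3[nH]cc(-c4nnc(-c5ccc(F)cc5)o4)c(=O)c3c2)cc1` — 15.7%
compound 2 `Cc1ccc(-c2nnc(-c3c[nH]c4ncc(-c5ccc(S(C)(=O)=O)cc5)cc4c3=O)o2)cc1` — 18.5%
compound 3 `O=c1c(-c2nnc(-c3ccc(Cl)cc3)o2)c[nH]c2ncc(-c3ccccc3)cc12` — 31.3%

In a functional assay on HeLa cells (Homo sapiens) for inhibition, read by MTT assay, with a stated time of 24 h, tested at 10 uM (on this read-out lower numbers stand for less inhibition of growth and higher numbers for more inhibition of growth at the one concentration tested), compound 2 gives 18.5%, the second highest of the three numbers; compound 1 lies nearest, within the scatter, and compound 3 furthest, beyond it. Going by the values given here, the only measured single-point step is a number 2.8 percentage points higher from compound 1 to compound 2 (within the scatter), a change on the same outer ring that stayed within the scatter.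

Compound 4 `Cc1cccc(-c2nnc(-c3c[nH]c4ncc(-c5ccc(S(C)(=O)=O)cc5)cc4c3=O)o2)c1` differs from compound 2 by 3-methylphenyl in place of 4-methylphenyl on an aromatic carbon. Among the compounds with values here, no measured pair moves a methyl around that ring, so the step from compound 1 to compound 2 bears on it only loosely, and it points to a small effect. The expected step is a number 1.5 percentage points higher from compound 2 to compound 4 (within the scatter), not beyond the scatter. Compound 4 is therefore estimated at 20%, between 8% and 35%.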

Compound 4, percent growth inhibition at one concentration: 2.57%
The estimate for compound 4 lay 17.4 percentage points above the measured number; measured number below the stated range.
By their numbers in this assay, from the lowest: compound 4; then compounds 1 and 2 (each within the scatter of the next); then compound 3.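

In this assay, 3-methylphenyl in place of 4-methylphenyl on the aromatic carbon of the five-membered ring gives a number 15.9 percentage points lower from compound 2 to compound 4 (beyond the scatter) with the same atoms, so the attachment pattern of the methyl on this outer ring matters, which the swap of fluoro for methyl did not show. Against the 4-fluorophenyl analogue, the same ring change gives a number 13.1 percentage points lower from compound 1 to compound 4 (beyond the scatter) in this series. Nothing available here accounts for these drops.

From the compounds shown here alone, whether any other group at the 3-position of this outer ring gives similarly low inhibition stays open. An amine or a carboxylic acid there would test this.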